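The source may report more compounds than this note shows. Statements on the series, on what has been measured and on what is new or still open speak of the compounds shown alone.

Two measured compounds anchor this account. Compound 1 `CCCNc1nc(-c2ccccc2)nc2c1nnn2Cc1ccccc1F` gives 3200000 nM in an assay on isolated protein for binding affinity to adenosine receptor A1 (Bos taurus); a lower number here means a stronger inhibitor, a higher number a weaker inhibitor. Compound 2 `OCCCNc1nc(-c2ccccc2)nc2c1nnn2Cc1ccccc1` gives 21400000 nM in this assay, the higher of the two numbers, and compound 1 is the nearer neighbour; the gap between them lies beyond the scatter, but the two structures differ in more than one place, so the pair says nothing about any single change.

The step under examination leads from compound 2 to compound 3 `OCCCNc1nc(-c2ccccc2)nc2c1nnn2Cc1ccccc1F`. The change is fluoro in place of hydrogen on an aromatic carbon, which is fluoro in place of hydrogen on an aromatic carbon. Among the measured compounds shown here, no measured pair isolates this change, so the expectation can rest only on the numbers above.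

For the measured compounds named here, for compound 3, a small lowering is expected, a 2.1-fold lower number from compound 2 to compound 3 (0.33 log units; beyond the scatter), since compound 1, the only compound carrying the 2-fluorobenzyl group, gave the lower of the two numbers with 3200000 nM. Compound 3 is therefore estimated at 10000000 nM, with a range from 3000000 nM to 30000000 nM.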

Compound 3, inhibition constant: 3700000 nM
Compound 3: middle estimate off by 2.7-fold (0.43 log units), on the high side; the range from low to high includes it.
By their numbers in this assay, from the lowest: compounds 1 and 3 (each within the scatter of the next); then compound 2.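

Held on the hydroxypropyl chain, the change from benzyl to 2-fluorobenzyl gives a clean single-change reading in this assay: a 5.8-fold lower number from compound 2 to compound 3 (0.76 log units; beyond the scatter), so fluoro on this aromatic carbon counts for something measurable, though the numbers remain very high. The other new step, hydroxy in place of hydrogen on the chain with the 2-fluorobenzyl group in place, reads a 1.2-fold higher number from compound 1 to compound 3 (0.06 log units; within the scatter), so in this setting the hydroxy group makes no difference that can be told from the scatter. No measurement at hand explains either step.

The compounds shown leave open whether chloro or methyl on this same carbon would give a step like that of fluoro, and whether fluoro elsewhere on the ring would do so. They also leave open how an amine at the end of the chain, or a longer chain, would read alongside the 2-fluorobenzyl group.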